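The compounds below may be only part of what the source reports. "The series", "measured", "known", "first", "only" and "open" are said of these compounds alone.

Measured so far:
- compound 1 `CCCCOc1ccc(C(=O)Nc2cc3ccc(OC4CCN(C)CC4)c(C)c3oc2=O)cc1CC=C(C)C` at 1400 nM
- compound 2 `Cc1c(OC2CCN(C)CC2)ccc2cc(NC(=O)c3ccc(O)c(CCC(C)C)c3)c(=O)oc12` at 600 nM
- compound 3 `CC(=O)Oc1ccc(C(=O)Nc2cc3ccc(OC4CCN(C)CC4)c(C)c3oc2=O)cc1` at 1670 nM

All three values come from a functional assay on SK-BR-3 cells (Homo sapiens) for antiproliferative activity (on this read-out lower numbers stand for stronger inhibition and higher numbers for weaker inhibition), as the common read-out. Compound 3 lies within the scatter of compound 1, while compound 2 gives a lower number, beyond the scatter of compound 3. Compound 4 `CC(=O)Oc1ccc(C(=O)Nc2cc3ccc(OC4CCN(C)CC4)c(C)c3oc2=O)cc1Cl` has chloro in place of hydrogen on an aromatic carbon, ortho to an acetoxy group (chloro in place of hydrogen on an aromatic carbon), which turns 4-acetoxyphenyl into 4-acetoxy-3-chlorophenyl. Going by the values given here, no measured pair shows a change at one place, so the expectation rests on weak ground. No step beyond the scatter is expected, and any shift is expected to lean slightly toward stronger inhibition. The expected change is a 1.4-fold lower number from compound 3 to compound 4 (0.14 log units; within the scatter) on this estimate. For compound 4 the estimated value is 1200 nM with an expected range from 500 nM to 2800 nM in this read-out.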

Compound 4, half-maximal inhibitory concentration: 3500 nM
Beside the measured number, compound 4's estimate is 2.9-fold (0.46 log units) below it, outside the stated range (above it).
By their numbers in this assay, from the lowest: compound 2; then compounds 1 and 3 (each within the scatter of the next); then compound 4.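

In this assay the series gains its first pair differing in one place: chloro in place of hydrogen, on the aromatic carbon ortho to an acetoxy group, gives a 2.1-fold higher number from compound 3 to compound 4 (0.32 log units; beyond the scatter) and so a step toward weaker inhibition. This carbon is therefore not silent, since a single added chlorine moves the number beyond the scatter, though this rests on one pair only. Nothing at hand accounts for the step.

Still open, from the compounds shown here alone, is whether fluoro, a methyl group or an amine on this carbon would shift the number in the same direction. Also open, going by these compounds, is whether chloro would cost as much with a longer chain in place of the acetoxy group.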